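A few compounds are considered here, and "the series" means these few. Any claim that something is new, unique, unknown or untested is made for them only; others in the source may bear on it.

Notes on the series.

Compound 1 `C/C=C/C(=O)Nc1cc2c(N3CCc4ccccc43)ncnc2cc1O[C@@H]1CCOC1` and compound 2 `C/C=C/C(=O)Nc1cc2c(N3CCCc4ccccc43)ncnc2cc1O[C@@H]1CCOC1` share one core and differ in a single place: 1,2,3,4-tetrahydroquinolin-1-yl in place of 2,3-dihydro-1H-indol-1-yl on an aromatic carbon. In a functional assay on PC-3 cells (Homo sapiens) for antiproliferative activity, read by MTT assay, with a stated time of 72 h (on this read-out higher numbers stand for weaker inhibition and lower numbers for stronger inhibition), compound 1 gives 5220 nM. In this assay compound 2 gives 9350 nM. The change made a 1.8-fold higher number from compound 1 to compound 2 (0.25 log units; within the scatter), so the two numbers cannot be set in order against each other.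

Compound 3 `COc1cc2ncnc(N3CCc4ccccc43)c2cc1NC(=O)/C=C/CN(C)C` is built on a different core; how its core differs from the core of compound 1 is not broken down here. In this assay compound 3 gives 2190 nM, the lowest number of the three, with compound 1 and compound 2 both standing higher by more than the scatter.

Compound 4 `COc1cc2ncnc(N3CCCc4ccccc43)c2cc1NC(=O)/C=C/CN(C)C` is not yet measured. It arises from compound 3 by 1,2,3,4-tetrahydroquinolin-1-yl in place of 2,3-dihydro-1H-indol-1-yl on an aromatic carbon, which is the same change, at the same place on the core, as that made between compound 1 and compound 2. Among the measured compounds shown here, the only measured instance of this change gave a 1.8-fold higher number from compound 1 to compound 2 (0.25 log units; within the scatter), a step that sits within the scatter, and the expectation for compound 4 rests on that instance alone. The step expected in this assay is a 1.8-fold higher number from compound 3 to compound 4 (0.26 log units; within the scatter). Compound 4 is therefore expected to give about 4000 nM in this assay, with a likely range from 2200 nM to 7500 nM. Whether the second core carries the change the same way remains to be seen once the number is in hand.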

Compound 4, half-maximal inhibitory concentration: 1750 nM
Estimate against measurement, compound 4: 2.3-fold (0.36 log units) above; the whole stated range lies above it.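

In this assay, 1,2,3,4-tetrahydroquinolin-1-yl in place of 2,3-dihydro-1H-indol-1-yl gives a 1.3-fold lower number from compound 3 to compound 4 (0.10 log units; within the scatter), so the two numbers cannot be set in order against each other. Set beside the earlier instance, the two steps cannot be told apart, and nothing here separates how the two cores carry the change: the same change on two cores in this assay, a 1.8-fold higher number (0.25 log units; within the scatter) from compound 1 to compound 2 and a 1.3-fold lower number (0.10 log units; within the scatter) from compound 3 to compound 4, 2.2-fold (0.35 log units) apart, within the scatter of two such steps. This shows that, in these two pairs, the change produced no step beyond the scatter on either core, and so gives no sign of a core-dependent outcome; it does not show that the change is without effect or that the cores respond alike, since two small steps could hide a real difference, and two pairs cannot speak for other cores in the series.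

The compounds shown leave open whether a step beyond the scatter appears at this place, on an aromatic carbon next to the ring nitrogen, with a group of another kind, such as an open-chain amine or an ether. They also leave open which of the features separating the two cores bears on the numbers, since no pair shown isolates any one of them.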